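Swapping Iodine for Methoxy on an Acid Amidase Inhibitor

The source may hold more compounds than are shown below. What is called first, only, known or untested is meant among the compounds shown, and "the series" means these compounds.

Compound 1 `O=C(CCCCCc1cccc(I)c1)N1CCOC1=O` carries an iodo group on its aromatic ring and was tested in an assay on HEK293 cells for inhibition of N-acylethanolamine-hydrolyzing acid amidase (Rattus norvegicus), read by LC-MS, with a stated time of 30 min (on this read-out lower numbers stand for stronger inhibition and higher numbers for weaker inhibition), where compound 1 gives 3120 nM. Among the measured compounds shown here, that is the only plain number in this set. Compound 2 `O=C(CCCCCc1ccc(O)c(Cl)c1)N1CCOC1=O`, which bears hydroxy and chloro groups on its ring, reached only the limit of the measurement, and in this assay compound 2 is reported as > 20000 nM. Compound 1 therefore stands as the sole measured point, with one further value that is a limit rather than a number (the limit of > 20000 nM in this assay, at which 1 of the 2 values shown sits). Compound 3 `COc1cccc(CCCCCC(=O)N2CCOC2=O)c1` is not yet measured; it differs from compound 1 in one place: methoxy in place of iodo on an aromatic carbon. For the measured compounds named here, no step between two measured compounds exists to guide the size of this change. The step of a 2.6-fold higher number from compound 1 to compound 3 (0.41 log units; beyond the scatter) is expected to run toward weaker inhibition, beyond the usual scatter. Compound 3 is accordingly estimated at 8000 nM, within 2500 nM to 25000 nM.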

Compound 3, half-maximal inhibitory concentration: 16300 nM
The estimate for compound 3 lay 2.0-fold (0.31 log units) below the measured number; low and high end bracket the measured number.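

Among the compounds shown here, this result gives the first measured step at this position: in this assay, replacing iodo with methoxy on the aromatic carbon gives a 5.2-fold higher number from compound 1 to compound 3 (0.72 log units; beyond the scatter), toward weaker inhibition. The inhibition read-out therefore responds to what sits at this place on the ring, and compound 1 with its iodo group is the better of the pair, although the swap adds only one heavy atom and one hydrogen-bond acceptor. Compound 2 gives only a limit of the assay, not a number, so it adds no second step: the limit of > 20000 nM in this assay, at which 1 of the 3 values shown sits.

A single swap cannot show whether the size of the group, its oxygen or something else accounts for the step. From the compounds shown here alone, whether bromo, an amine or a carboxylic acid at this place would match or improve on iodo remains open.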